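A few compounds are considered here, and "the series" means these few. Any claim that something is new, unique, unknown or untested is made for them only; others in the source may bear on it.

In an assay on microsomes from brain for inhibition of Fatty-acid amide hydrolase 1 (Rattus norvegicus), read by fluorescence and HPLC, with a stated time of 60 min (on this read-out higher numbers stand for weaker inhibition and lower numbers for stronger inhibition), two compounds have been measured so far. Compound 1 `CCCCCCCCc1ccc(OC(C)C(=O)Cn2nnc(-c3ccccc3)n2)cc1` gives 24 nM. Compound 2 `CC(Oc1ccc(Oc2ccc(Cl)cc2)cc1)C(=O)Cn1nnc(-c2ccccc2)n1` carries a 4-chlorophenoxy group in place of the octyl chain of compound 1. For the measured compounds named here, compound 2 gives 51 nM, the higher of the two numbers; the one step recorded, a 2.1-fold higher number from compound 1 to compound 2 (0.33 log units; beyond the scatter), is modest but lies beyond the scatter.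

Compound 3 `COC(=O)c1ccc(-c2nnn(CC(=O)C(C)Oc3ccc(Oc4ccc(Cl)cc4)cc3)n2)cc1` is the next compound to be measured in this assay. It differs from compound 2 in a single place: methoxycarbonyl in place of hydrogen on an aromatic carbon. The phenyl ring attached to the shared core thus becomes a 4-(methoxycarbonyl)phenyl ring, while the rest of the molecule is unchanged.

Going by the values given here, no measured step speaks directly to this change. Among the compounds with values here, the only step available, from compound 1 to compound 2, alters the other end of the molecule, the part bearing the octyl or 4-chlorophenoxy group, and says nothing about substitution on the phenyl ring of the core. The expectation for compound 3 therefore rests on the number of compound 2 alone, with a wide margin: a step of a 1.2-fold higher number from compound 2 to compound 3 (0.07 log units; within the scatter) is estimated, which is within the scatter, so no shift beyond it is expected in either direction. Compound 3 is estimated to give 60 nM in this assay, with a likely range from 20 nM to 180 nM.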

Compound 3, half-maximal inhibitory concentration: 47 nM
Compound 3: the middle estimate sits 1.3-fold (0.11 log units) above what was measured, and the stated range covers the measured number.
By their numbers in this assay, from the lowest: compounds 1, 3 and 2 (each within the scatter of the next, the first and the last beyond it).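

For the compounds shown here, until now, the only change seen was at the end of the molecule bearing the octyl or 4-chlorophenoxy group; compound 3 is the first to alter the phenyl ring on the shared core. In this assay, going from phenyl to 4-(methoxycarbonyl)phenyl gives a 1.1-fold lower number from compound 2 to compound 3 (0.04 log units; within the scatter) and so, for this one pair, shows that a methoxycarbonyl group on this aromatic carbon, para to a large group, brings no change that can be told apart from the scatter of repeated measurements. Nothing available here explains this result.

One pair cannot show whether this position would tolerate any other group in the same way: a carboxylic acid, an amine or a longer chain in the place of methoxycarbonyl might leave the number where it is or move it in either direction. Going by these compounds, it also remains open whether methoxycarbonyl would have the same small effect on the phenyl ring of compound 1, which carries the octyl chain instead of the 4-chlorophenoxy group.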